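The source may report more compounds than this note shows. Statements on the series, on what has been measured and on what is new or still open speak of the compounds shown alone.

Compound 1 `COc1cc2cc(C(=O)CCC3CC[N+](C)(Cc4ccccc4)CC3)sc2cc1OC` gives 2000 ug/mL in a physicochemical assay for solubility; a lower number here means a less soluble compound, a higher number a more soluble compound. Compound 3 `COc1cc2cc(C(=O)CC(OC)C3CC[N+](C)(Cc4ccccc4)CC3)sc2cc1OC`, with methoxy in place of hydrogen on a saturated chain carbon bound to a saturated chain carbon and a saturated ring carbon, gives 1500 ug/mL, and the step of a 1.3-fold lower number from compound 1 to compound 3 (0.12 log units; within the scatter) lies within the scatter. Compound 2 `COc1cc2cc(C(=O)CC(O)C3CC[N+](C)(Cc4ccccc4)CC3)sc2cc1OC` has been measured repeatedly, giving 10000 ug/mL; 8000 ug/mL; 10000 ug/mL (3 entries); these repeated entries (the several entries of compound 2 in this assay, 10000 ug/mL; 8000 ug/mL; 10000 ug/mL (3 entries)) sit higher than the numbers for compound 1 and compound 3. Compound 4 `COC(=O)C[N+]1(C)CCC(CCC(=O)c2cc3cc(OC)c(OC)cc3s2)CC1` differs from compound 1 elsewhere: methoxycarbonyl in place of phenyl on a saturated chain carbon bound to an amine nitrogen in a ring, or, cut one bond further out, benzyl to (methoxycarbonyl)methyl. For the measured compounds named here, no measured step touches this part of the molecule, so the only known step is no direct guide. A moderate rise is nevertheless expected, a 2.0-fold higher number from compound 1 to compound 4 (0.30 log units; within the scatter). Compound 4 is estimated at 4000 ug/mL, with a range from 1500 ug/mL to 10000 ug/mL.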

Compound 4, solubility: 60000 ug/mL
Beside the measured number, compound 4's estimate is 15-fold (1.18 log units) below it, outside the stated range (above it).
By their numbers in this assay, from the lowest: compounds 3 and 1 (each within the scatter of the next); then compound 4.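

For the compounds shown here, putting methoxycarbonyl in place of phenyl on a saturated chain carbon bound to an amine nitrogen in a ring gives a 30-fold higher number from compound 1 to compound 4 (1.48 log units; beyond the scatter) in this assay, so this position can move the read-out strongly, which no earlier step had tested. The change removes an aromatic ring and adds hydrogen-bond acceptors together, and this single step cannot separate the two. Nothing measured here accounts for the rise.

Going by these compounds, how a carboxylic acid or an amide would read at this place remains open. So does the effect of a longer chain.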